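Oxadiazole to Thiadiazole: a Step Expected to Stay Small

The source may hold more compounds than are shown below. What is called first, only, known or untested is meant among the compounds shown, and "the series" means these compounds.

Of the compounds shown here, two have been measured in a functional assay on UACC-257 cells (Homo sapiens); a higher number here means a weaker inhibitor of growth, a lower number a stronger inhibitor of growth. Compound 1 `COc1cc(CSc2cc(Cl)c(-c3nc(-c4ccc(Cl)cc4)no3)cc2S(=O)(=O)NC(=N)NO)cc(OC)c1OC` gives 9330 nM in this assay, the higher of the two numbers. Compound 2 `N=C(NO)NS(=O)(=O)c1cc(-c2nc(-c3ccccc3)no2)c(Cl)cc1SCc1ccccc1` gives 1680 nM, and the gap between these two values lies beyond the scatter. Among the compounds with values here, the two compounds differ in more than one place, so no single step links them.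

Compound 3 `COc1cc(CSc2cc(Cl)c(-c3nnc(-c4ccc(Cl)cc4)s3)cc2S(=O)(=O)NC(=N)NO)cc(OC)c1OC` has not yet been measured. It differs from compound 1 in one place: 5-(4-chlorophenyl)-1,3,4-thiadiazol-2-yl in place of 3-(4-chlorophenyl)-1,2,4-oxadiazol-5-yl on an aromatic carbon. The leaving and entering groups match in size and in hydrogen-bond acceptors; the oxygen of the five-membered ring gives way to sulfur. Within the data shown here, no measured pair shows what such an exchange does here, so the expectation rests on the weak inhibition of compound 1 alone. The step of a 1.2-fold lower number from compound 1 to compound 3 (0.09 log units; within the scatter) is expected to be small, in either direction, and most likely within the scatter. Compound 3 is accordingly estimated at 7500 nM, within a range from 2500 nM to 22000 nM.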

Compound 3, concentration for 50% growth inhibition: 26300 nM
For compound 3 the middle estimate is 3.5-fold (0.54 log units) below the measured one; the measured number lies above the stated range.
By their numbers in this assay, from the lowest: compound 2; then compound 1; then compound 3.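

Placing 5-(4-chlorophenyl)-1,3,4-thiadiazol-2-yl in place of 3-(4-chlorophenyl)-1,2,4-oxadiazol-5-yl is the first single change that can be read at this position, and in this assay it gives a 2.8-fold higher number from compound 1 to compound 3 (0.45 log units; beyond the scatter). The position, on an aromatic carbon ortho to a chloro group, therefore responds to this exchange even though the heavy-atom and hydrogen-bond acceptor counts stay the same. Nothing available explains why the number rises.

The exchange replaces oxygen with sulfur and also rearranges the ring atoms, so this one step cannot separate those two differences. Also open, from the compounds shown here alone, are whether the step would keep its size on the rest of compound 2, and how an amide or a methyl ester on that aromatic carbon would compare with either five-membered ring.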